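Methoxy-to-Fluoro Swap on Triazolothiadiazine Inhibitors of MCF7 Growth

The source may hold more compounds than are shown below. What is called first, only, known or untested is meant among the compounds shown, and "the series" means these compounds.

Compound 1 `COc1ccc(C2=Nn3c(nnc3C(C)c3ccc(-c4ccccc4)c(F)c3)SC2)cc1`: 2600 nM
Compound 2 `CC(c1ccc(-c2ccccc2)c(F)c1)c1nnc2n1N=C(c1ccc(F)cc1)CS2`: 8100 nM
Compound 3 `COc1ccc(C2=Nn3c(nnc3C(C)c3ccc(CC(C)C)cc3)SC2)cc1`: 5200 nM

Three compounds were tested in a functional assay on MCF7 cells (Homo sapiens) for inhibition, read by sulforhodamine B assay, with a stated time of 72 h; a lower number here means a stronger inhibitor, a higher number a weaker inhibitor. Compound 1 gives 2600 nM, compound 2 gives 8100 nM, and compound 3 gives 5200 nM. Compound 2 differs from compound 1 by fluoro in place of methoxy on an aromatic carbon, and the result is a 3.1-fold higher number from compound 1 to compound 2 (0.49 log units; beyond the scatter). The difference between the core of compound 1 and the core of compound 3 is not broken down here.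

Compound 4 `CC(C)Cc1ccc(C(C)c2nnc3n2N=C(c2ccc(F)cc2)CS3)cc1` is not yet measured. It differs from compound 3 by fluoro in place of methoxy on an aromatic carbon, the same change that turns compound 1 into compound 2, at the same place. Among the measured compounds shown here, since the one measured example of this change weakened inhibition, the account rests on it: compound 4 is expected to be a weaker inhibitor than compound 3, with an estimated step of a 2.7-fold higher number from compound 3 to compound 4 (0.43 log units; beyond the scatter), because the change from compound 1 to compound 2 gave a 3.1-fold higher number from compound 1 to compound 2 (0.49 log units; beyond the scatter). Compound 4 is therefore estimated at 14000 nM, with a range from 6000 nM to 35000 nM in this assay.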

Compound 4, half-maximal inhibitory concentration: 8900 nM
Compound 4: middle estimate off by 1.6-fold (0.20 log units), on the high side; the range from low to high includes it.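

In this assay, the change from 4-methoxyphenyl to 4-fluorophenyl on the core of compound 3 gives a 1.7-fold higher number from compound 3 to compound 4 (0.23 log units; within the scatter), so on this core alone the step cannot be told apart from the usual spread of repeated measurements. Set beside a 3.1-fold higher number from compound 1 to compound 2 (0.49 log units; beyond the scatter), it does not differ from the earlier step, so the two cores give no sign that the change behaves differently from one to the other: the same change on two cores in this assay, a 3.1-fold higher number (0.49 log units; beyond the scatter) from compound 1 to compound 2 and a 1.7-fold higher number (0.23 log units; within the scatter) from compound 3 to compound 4, 1.8-fold (0.26 log units) apart, within the scatter of two such steps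

This does not show that the change has one fixed size, since one step lies beyond the scatter and the other within it, and two pairs set no rule for any further core in the series.

The compounds shown leave open how other groups at this place would read, such as chloro, hydroxyl or an amine in place of methoxy or fluoro. Also open, going by these compounds, is whether the step would hold on a core carrying a carboxylic acid or a longer chain where compound 1 and compound 3 differ.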